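Phenol analogue in the cytotoxicity series

The compounds below may be only part of what the source reports. "The series", "measured", "known", "first", "only" and "open" are said of these compounds alone.

The shared core is carried by compound 1 `CCOC(=O)c1c(-c2cc(F)cc(OC)c2)[nH]c2cc(OC)ccc2c1=O`, compound 2 `CCOC(=O)c1c(-c2cccc(OC(C)C)c2)[nH]c2cc(OC)ccc2c1=O` and compound 3 `CCOC(=O)c1c(-c2cccc(OC(F)(F)F)c2)[nH]c2cc(OC)ccc2c1=O`. In an ADME assay on Raji cells (Homo sapiens) for cytotoxicity, read by luminescence, with a stated time of 72 h (on this read-out lower numbers stand for an effect already at smaller amounts and higher numbers for an effect only at larger amounts of compound), compound 1 reaches only the limit > 21500 nM. Compound 2 likewise stops at the limit > 21500 nM in this assay. Compound 3 gives the limit > 21500 nM in this assay. Hence (the limit of > 21500 nM in this assay, at which 3 of the 3 values shown sit), and compound 2 has no number to place it, only that limit. The step that the two limits leave unreadable from compound 2 to compound 3 is unreadable in size. Compound 4 `CCOC(=O)c1c(-c2cccc(O)c2)[nH]c2cc(OC)ccc2c1=O` differs from compound 2 by hydrogen in place of isopropyl on an oxygen on an aromatic ring. Among the measured compounds shown here, no measured step bears readably on this change, as every value so far is a limit. Compound 4 is expected to give 30000 nM (range 15000 nM to 100000 nM), most likely again as a limit. The expected step that the limit leaves unreadable from compound 2 to compound 4 is none beyond the scatter.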

Compound 4, half-maximal effective concentration: > 21500 nM
Compound 4: no number, only a limit (the forecaster's own chance of this, stated with the estimate: 85%); the middle value lies beyond the limit too.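

No step can be read among compound 1, compound 2, compound 3 and compound 4, as each gives only a limit: the limit of > 21500 nM in this assay, at which 4 of the 4 values shown sit.

Whether any of these compounds reaches a numerical value in this assay, and how their ring substituents would then compare, stays open.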